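Series notes: aryl-to-cycloalkyl swap on one amide carbonyl

The source may hold more compounds than are shown below. What is called first, only, known or untested is meant among the compounds shown, and "the series" means these compounds.

Compound 3 `O=C(Nc1cccc(NC(=O)c2ccc(Cl)c(Cl)c2)c1)c1cccc(Cl)c1` carries a 3-chlorophenyl on one carbonyl carbon and a 3,4-dichlorophenyl on the other. In an in vitro functional assay on HEK293-A cells for antagonist activity at metabotropic glutamate receptor 5 (Rattus norvegicus), read by calcium flux (on this read-out lower numbers stand for stronger inhibition and higher numbers for weaker inhibition), compound 3 gives > 30000 nM, which is a limit of the assay and not a number. Compound 1 `COc1ccccc1C(=O)Nc1cccc(NC(=O)c2ccc(Cl)c(Cl)c2)c1` gives > 30000 nM in this assay, again a limit. Compound 2 `COc1ccccc1C(=O)Nc1cccc(NC(=O)C2CCC2)c1` gives > 30000 nM, also a limit. All three values sit at the same place, as the limit of > 30000 nM in this assay, at which 3 of the 3 values shown sit, records, so compound 3 can be placed no more precisely than at that limit.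

Compound 4 `O=C(Nc1cccc(NC(=O)C2CCCCC2)c1)c1cccc(Cl)c1` differs from compound 3 in one place: cyclohexyl in place of 3,4-dichlorophenyl on a carbonyl carbon. The measured step that most resembles this change is a step that the two limits leave unreadable from compound 1 to compound 2, where a cyclobutyl took the place of the same 3,4-dichlorophenyl on a carbonyl carbon; the other measured step, a step that the two limits leave unreadable from compound 1 to compound 3, concerns the second carbonyl. Neither step can be read in size: both of its ends are limits. Within the data shown here, no measured step therefore gives a direction, and nothing among the three compounds suggests that a cyclohexyl would bring the value under the limit. Compound 4 is expected to remain at the limit in this assay, an estimated step that the limit leaves unreadable from compound 3 to compound 4. The estimate for compound 4 is 50000 nM, with a range from 20000 nM to 200000 nM.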

Compound 4, half-maximal inhibitory concentration: > 30000 nM
Compound 4: only a limit was reported (the forecaster's own chance of this, stated with the estimate: 85%); the middle value does not contradict the limit.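

In this assay compound 4 gives > 30000 nM, a limit of the assay and not a number, so the step from compound 3 to compound 4 cannot be read in size. The compounds shown leave open which change to the shared core, if any, would give a readable value, as every record sits at one place: the limit of > 30000 nM in this assay, at which 4 of the 4 values shown sit.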